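The source may report more compounds than this note shows. Statements on the series, on what has been measured and on what is new or still open speak of the compounds shown alone.

Compound 2 `O=C1NCc2c1c1c(c3c2c2ccccc2n3CCO)CCc2cc(OCC3CC3)ccc2-1` is examined in an assay on isolated protein for inhibition of mitogen-activated protein kinase kinase kinase 9 (Homo sapiens), tested at 1 uM (on this read-out higher numbers stand for more inhibition at the one concentration tested (going by the name of the read-out) and lower numbers for less inhibition), where compound 2 gives 30%. This is the higher of the two numbers in hand; the other belongs to compound 1 `O=C1NCc2c1c1c(c3[nH]c4ccccc4c23)CCc2cc(O)ccc2-1`, which in this assay gives 9%, a number that lies beyond the scatter below it. Compound 3 `COCCOc1ccc2c(c1)CCc1c-2c2c(c3c4ccccc4n(CCO)c13)CNC2=O` has not yet been measured. It differs from compound 2 in one place: methoxymethyl in place of cyclopropyl on a saturated chain carbon bound to an oxygen on an aromatic ring. No measured pair in this set isolates such a change, so its effect cannot be read from the numbers shown. The change sits on a saturated chain carbon bound to an oxygen on an aromatic ring and leaves the rest of compound 2 intact. In this assay the expected step is therefore a number 5 percentage points lower from compound 2 to compound 3 (within the scatter), a slight drop at most and not clearly beyond the scatter. Compound 3 is expected to give about 25%, within a range from 10% to 40%.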

Compound 3, a percentage reported as inhibition, at one concentration (the size of the read-out at that concentration, not a potency): 52%
For compound 3 the middle estimate is 27 percentage points below the measured one; the whole stated range lies below it.
By their numbers in this assay, from the lowest: compound 1; then compound 2; then compound 3.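

In this assay, putting methoxymethyl in place of cyclopropyl on a saturated chain carbon bound to an oxygen on an aromatic ring comes with a number 22 percentage points higher from compound 2 to compound 3 (beyond the scatter) and so shows that the read-out responds to what this position carries. The two groups match in heavy-atom count, but cyclopropyl has a ring and no hydrogen-bond acceptor, whereas methoxymethyl has no ring and one hydrogen-bond acceptor. Nothing on hand says which of these differences accounts for the step. As far as these compounds go, it remains open whether the ether oxygen or the loss of the ring matters, and how an amine, a carboxylic acid or a longer chain ending in methoxy would read at this place. Steps involving compound 1 cannot be read, since it differs from the other compounds in more than one place.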